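The source may hold more compounds than are shown below. What is called first, only, known or untested is meant among the compounds shown, and "the series" means these compounds.

compound 1 `CC(C)=CCC/C(C)=C/CC/C(C)=C/CSC[C@H](NC(=O)CCCCCN1CCCC1)C(=O)NC1CCCC1`: 6800 nM
compound 2 `CC(C)=CCC/C(C)=C/CC/C(C)=C/CSc1ccccc1C(N)=O`: > 20000 nM (a limit)
compound 3 `CC(C)=CCC/C(C)=C/CC/C(C)=C/CSC[C@H](NC(=O)CCCCCN1CCN(C)CC1)C(=O)NC1CCCC1`: > 20000 nM (a limit)

Only compound 1 has a true number in a functional assay on BXPC-3 cells (Homo sapiens) for cytotoxicity, read by fluorescence, with a stated time of 48 h (on this read-out lower numbers stand for an effect already at smaller amounts and higher numbers for an effect only at larger amounts of compound), so it is the sole firm reference point. Compound 2 and compound 3 carry no number, only (the limit of > 20000 nM in this assay, at which 2 of the 3 values shown sit).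

The next molecule, compound 4 `CC(C)=CCC/C(C)=C/CC/C(C)=C/CSC[C@H](NC(=O)CCCCCN1CCCC1)C(=O)NC1CC1`, keeps the core of compound 1 and alters one group: cyclopropyl in place of cyclopentyl on an amide-type nitrogen. In words, this is cyclopropyl in place of cyclopentyl on an amide-type nitrogen.

Within the data shown here, the only measured step is an at least 2.9-fold higher number from compound 1 to compound 3 (0.46 log units; beyond the scatter). It swaps 4-methylpiperazin-1-yl in place of pyrrolidin-1-yl on a saturated chain carbon, which is a different place in the molecule. It therefore bears on the new change only indirectly, showing that a single swap can move the number of compound 1 beyond the scatter. Among the measured compounds shown here, no measured step touches the group on the amide nitrogen, so the size of this step is a judgement. With nothing closer to go on, a small move towards a higher number is expected, most likely not beyond the scatter, and a result at the limit remains possible.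

The expected change is a 1.4-fold higher number from compound 1 to compound 4 (0.15 log units; within the scatter). For compound 4 the estimated value is 9500 nM, with an expected range of 4000 nM to 20000 nM.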

Compound 4, half-maximal effective concentration: > 20000 nM
Compound 4: only a limit was reported; the forecaster's own chance of this, stated with the estimate: 20%; at least 2.1-fold (0.32 log units) between middle value and limit.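

In this assay, the group on the amide-type nitrogen proves to matter, as cyclopropyl in place of cyclopentyl gives an at least 2.9-fold higher number from compound 1 to compound 4 (0.46 log units; beyond the scatter). Among these compounds, earlier, the only measured step was the swap from pyrrolidin-1-yl to 4-methylpiperazin-1-yl, so this is a second place in the molecule where a single change moves the number beyond the scatter, and here the three-membered ring does worse than the five-membered ring. The value of compound 4, > 20000 nM, is a limit and not a number: the limit of > 20000 nM in this assay, at which 3 of the 4 values shown sit.

Among the compounds shown here, with only two groups compared at this nitrogen, no trend with ring size can be drawn, and a six-membered ring such as cyclohexyl, an open chain such as isopropyl or an aromatic ring such as phenyl could each fall on either side of compound 1. On these data alone, it also remains open how far compound 4 truly lies from compound 1, and whether cyclopropyl could be tolerated when paired with a different amine at the chain end, such as piperidin-1-yl or dimethylamino.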